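A Difluorophenoxy Swap on a Jurkat Cell Inhibitor

A few compounds are considered here, and "the series" means these few. Any claim that something is new, unique, unknown or untested is made for them only; others in the source may bear on it.

Of the compounds shown here, two from this series have been measured in a functional assay on Jurkat cells (Homo sapiens); a higher number here means a weaker inhibitor, a lower number a stronger inhibitor. Compound 1, `CC(C)[C@H](NC(=O)COc1cccc2ccccc12)C(=O)N[C@@H](CC(=O)O)C(=O)COc1ccc(Oc2ccccc2)cc1`, gives 12700 nM. Compound 2, `CC(=O)Nc1cccc(OCC(=O)[C@H](CC(=O)O)NC(=O)[C@@H](NC(=O)COc2cccc3ccccc23)C(C)C)c1`, reaches only a limit of the assay, > 100000 nM, so no number is known for it. That limit is where compound 2 stands among the values shown, as the one of the two that sits at the limit of > 100000 nM in this assay, at which 1 of the 2 values shown sits.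

Compound 3, `CC(C)[C@H](NC(=O)COc1cccc2ccccc12)C(=O)N[C@@H](CC(=O)O)C(=O)COc1cc(F)cc(F)c1`, has not yet been measured. It differs from compound 2 in one place, (3,5-difluorophenyl in place of 3-acetamidophenyl on an oxygen on a saturated carbon).

Among the measured compounds shown here, no step between two measured compounds is available, so the expectation for compound 3 rests on what is seen for compound 1 and compound 2. Compound 3 is expected to return a number rather than a limit, landing nearer to compound 1 than to compound 2, an expected step of an at least 6.6-fold lower number from compound 2 to compound 3 (0.82 log units; beyond the scatter) in this assay. Compound 3 is therefore estimated at 15000 nM, with a range from 3000 nM to 70000 nM.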

Compound 3, half-maximal inhibitory concentration: > 100000 nM
Compound 3 gave a limit, no number; the forecaster's own chance of this, stated with the estimate: 25%; at least 6.6-fold (0.82 log units) between middle value and limit.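

In this assay compound 2 and compound 3 both stop at a limit rather than a number, so no step from one to the other can be read: the limit of > 100000 nM in this assay, at which 2 of the 3 values shown sit.

The compounds shown leave open how far apart 3,5-difluorophenyl and 3-acetamidophenyl really stand in this series, as neither compound carries a number that could show it.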